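Furan replaced by chlorophenyl on a fused dimedone-derived scaffold

The source may hold more compounds than are shown below. What is called first, only, known or untested is meant among the compounds shown, and "the series" means these compounds.

The study concerns three measured compounds and one that awaits measurement. Compound 1 `CC1(C)CC(=O)c2c(-c3ccc(F)cc3)cc(-c3ccccc3)nc2C1`, compound 2 `CC1(C)CC(=O)C2=C(C1)NC(c1ccccc1)=CC2c1ccco1` and compound 3 `CCOC(=O)C1=CC(c2ccc(Br)cc2)C2=C(CC(C)(C)CC2=O)N1` share the same core and differ in the groups attached to it. In an assay on isolated protein for inhibition of glucose-6-phosphatase catalytic subunit 1 (Homo sapiens), read by inositol phosphate accumulation, with a stated time of 30 min, tested at 100 uM (a higher number here means more inhibition at the concentration tested (going by the name of the read-out), a lower number less inhibition), compound 1 gives 11.1%. In the same assay compound 2 gives 11.4%, and compound 3 is reported as "not active" (no number reported), with no number attached. Of the two numbered results, compound 2 is the one reported higher, but the margin to compound 1 lies within the usual scatter of this assay, so the two cannot be separated. No pair of these compounds differs in a single place, so no step between measured compounds can be counted.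

The new compound is compound 4 `CC1(C)CC(=O)C2=C(C1)NC(c1ccccc1)=CC2c1ccc(Cl)cc1`. Relative to compound 2 the change is 4-chlorophenyl in place of furan-2-yl on a saturated ring carbon. For the measured compounds named here, nothing among the measured compounds isolates this exchange, and the two numbered results sit close together, so the expected step from compound 2 to compound 4 is none beyond the scatter. Compound 4 is therefore expected to give about 10%, within 0% to 25%. The estimated step of a number 1.4 percentage points lower from compound 2 to compound 4 (within the scatter) is small.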

Compound 4, a percentage reported as inhibition, at one concentration (the size of the read-out at that concentration, not a potency): 7.16%
Beside the measured number, compound 4's estimate is 2.8 percentage points above it; measured number inside the range.
By their numbers in this assay, from the lowest: compounds 4, 1 and 2 (each within the scatter of the next).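

In this assay, for the compounds shown here, 4-chlorophenyl in place of furan-2-yl on a saturated ring carbon gives a number 4.2 percentage points lower from compound 2 to compound 4 (within the scatter), and this is the first comparison in the set that changes a single place. At this carbon, then, the assay does not tell the two groups apart, even though the entering group has 7 heavy atoms against 5 and 0 hydrogen-bond acceptors against 1. No accompanying measurement offers an explanation for this result.

The compounds shown do not separate the change of aromatic ring from the presence of chlorine, as neither a plain phenyl nor a chlorine-free six-membered ring of any other kind stands at this carbon in compound 2 or compound 4. They also leave open whether a quite different group here, such as an amine, a carboxylic acid or a longer chain, would move the reading beyond the scatter, since the only exchange shown at this position stays within it.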